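The source may hold more compounds than are shown below. What is called first, only, known or untested is meant among the compounds shown, and "the series" means these compounds.

In a functional assay on HCT-116 cells (Homo sapiens) for antiproliferative activity, read by MTT assay, with a stated time of 48 h (a lower number here means a stronger inhibitor, a higher number a weaker inhibitor), compound 1 `COc1ccc(CN(C(=O)CSc2nc3ccccc3s2)c2cc(OC)c(OC)c(OC)c2)cc1C`, which carries a 4-methoxy-3-methylphenyl group, gives 17100 nM. Compound 2 `COc1cc(N(Cc2ccc(C)cc2)C(=O)CSc2nc3ccccc3s2)cc(OC)c1OC`, with 4-methylphenyl at that place, gives only a limit, > 80000 nM, and so has no number of its own. Compound 3 `COc1ccc(CN(C(=O)CSc2nc3ccccc3s2)c2cc(OC)c(OC)c(OC)c2)cc1[N+](=O)[O-]` has not yet been measured. It differs from compound 2 as follows: 4-methoxy-3-nitrophenyl in place of 4-methylphenyl on a saturated chain carbon bound to an amide-type nitrogen. In words, it has 4-methoxy-3-nitrophenyl in place of 4-methylphenyl on a saturated chain carbon bound to an amide-type nitrogen.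

Among the compounds with values here, only one measured step bears on this change, and it reads an at least 4.6-fold higher number from compound 1 to compound 2 (0.67 log units; beyond the scatter). Its size is a bound rather than an exact figure. The group entering compound 3 shares the 4-methoxy of the group in compound 1, which gives 17100 nM, although a nitro group takes the place of the methyl. A step of similar size towards a lower number is therefore expected in this assay, with a real chance that compound 3 also ends at the limit. The expected change is an at least 4.4-fold lower number from compound 2 to compound 3 (0.64 log units; beyond the scatter). For compound 3 the estimated value is 18000 nM, with an expected range from 4000 nM to 70000 nM.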

Compound 3, half-maximal inhibitory concentration: 1280 nM
Compound 3: middle estimate off by 14-fold (1.15 log units), on the high side; the whole stated range lies above it.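

In this assay, the cleanest reading comes from the pair that differs in one place only, with nitro in place of methyl on an aromatic carbon and the 4-methoxy kept: the result is a 13-fold lower number from compound 1 to compound 3 (1.13 log units; beyond the scatter). The 4-methoxy therefore does not set the level of activity alone, and the group that accompanies it on this aromatic ring matters a great deal. The full exchange of 4-methylbenzyl for 4-methoxy-3-nitrobenzyl gives an at least 62-fold lower number from compound 2 to compound 3 (1.79 log units; beyond the scatter), so the place on a saturated chain carbon bound to an amide-type nitrogen responds far more strongly than the first two compounds could show. The size of that step is a bound and not an exact figure, since compound 2 stands at a limit of the assay: the limit of > 80000 nM in this assay, at which 1 of the 3 values shown sits.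

The compounds shown leave open whether nitro itself is needed, or whether an amine, a nitrile or a carboxylic acid on the same aromatic carbon would serve equally well. They also leave open whether nitro keeps this gain without the 4-methoxy, as the two appear together here in compound 3.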